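The source may hold more compounds than are shown below. What is called first, only, known or untested is meant among the compounds shown, and "the series" means these compounds.

The shared core is a rhodanine bearing a diene that ends in a benzene ring; compound 1 `O=C1NC(=S)S/C1=C\C=C\c1ccccc1` is the parent, and compound 2 `O=C1NC(=S)S/C1=C\C=C\c1ccccc1OCc1ccccc1C(F)(F)F` carries on that ring a benzyloxy arm whose own ring bears a trifluoromethyl group. In an assay on isolated protein for inhibition of protein tyrosine phosphatase type IVA 3 (Homo sapiens), tested at 5 ug/mL (a higher number here means more inhibition at the concentration tested (going by the name of the read-out), a lower number less inhibition), compound 1 gives 37.4%. In this assay compound 2 gives 40.8%, the higher of the two numbers, yet the gap to compound 1 lies within the usual scatter, so the two cannot be told apart. The arm, in other words, has not shown any clear effect of its own.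

Compound 3 `COc1ccccc1COc1ccccc1/C=C/C=C1\SC(=S)NC1=O` differs from compound 2 in a single spot: methoxy in place of trifluoromethyl on an aromatic carbon. Because compound 1, which has no such arm at all, gives 37.4%, a change at the far end of that arm is expected to make little difference. The step from compound 2 to compound 3 in this assay is therefore expected to be a number 2.8 percentage points lower from compound 2 to compound 3 (within the scatter), none beyond the scatter. Compound 3 is expected to reach about 38%, with a likely range from 22% to 55%.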

Compound 3, a percentage reported as inhibition, at one concentration (the size of the read-out at that concentration, not a potency): 78.8%
Beside the measured number, compound 3's estimate is 40.8 percentage points below it; the whole stated range lies below it.
By their numbers in this assay, from the lowest: compounds 1 and 2 (each within the scatter of the next); then compound 3.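

In this assay, putting methoxy in place of trifluoromethyl on an aromatic carbon, ortho to a large group, gives a number 38 percentage points higher from compound 2 to compound 3 (beyond the scatter). Going by these compounds alone, this shows that the far end of the benzyloxy arm is a position where the choice of group clearly counts, something compound 2 could not reveal with only one group at that spot. Nothing measured here accounts for so large a step, so it stands as an observation about this one pair of compounds.

On these data alone, with only these two groups at this carbon, it remains open whether the gain belongs to methoxy specifically, or whether a hydroxyl, an ethoxy or an amine in the same place would do as well. As far as these compounds go, it is also open whether methoxy would give a similar number on another carbon of that ring, and whether a fluorine or a plain hydrogen at this spot would fall closer to compound 2 or to compound 3.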